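The compounds below may be only part of what the source reports. "The series", "measured", "known", "first", "only" and "open" are said of these compounds alone.

The three measured compounds share one core and are read in an assay on nucleic acid for inhibition of Nucleic Acid, read by fluorescence, tested at 100 uM; on this read-out lower numbers stand for less inhibition and higher numbers for more inhibition at the one concentration tested (going by the name of the read-out). Compound 1 `CCCCN(CCCC)Cc1cn(CC(O)COCc2ccccc2)nn1` gives 6% in this assay. Compound 2 `CN(Cc1cn(CC(O)COCc2ccccc2)nn1)CC1CCCCC1` gives 6% in this assay, and compound 3 `CN(CCCc1ccccc1)Cc1cn(CC(O)COCc2ccccc2)nn1` gives 18% in this assay. Compound 2 stands level with compound 1, the two together forming the lowest numbers of the three, as shown by no change at the digits printed from compound 1 to compound 2 (within the scatter); compound 3 lies above it, as shown by a number 12 percentage points higher from compound 2 to compound 3 (beyond the scatter).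

Compound 4 `CCCCNC(=O)OCC(O)Cn1cc(CN(C)CC2CCCCC2)nn1` differs from compound 2 at a different part of the molecule: butylcarbamoyl in place of benzyl on an oxygen on a saturated carbon. Neither measured step touches this oxygen-borne group. The step of no change at the digits printed from compound 1 to compound 2 (within the scatter) concerned the amine nitrogen and the step of a number 12 percentage points higher from compound 2 to compound 3 (beyond the scatter) concerned a substituent on that nitrogen, the first giving nothing beyond the scatter and the second a modest rise. Within the data shown here, no measured step therefore guides the change in compound 4, and the expectation for compound 4 is a step of a number 2 percentage points higher from compound 2 to compound 4 (within the scatter) that stays within the scatter. Compound 4 is accordingly estimated at 8%, with a range from 0% to 22%.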

Compound 4, a percentage reported as inhibition, at one concentration (the size of the read-out at that concentration, not a potency): 12%
Compound 4: the middle estimate sits 4 percentage points below what was measured; measured number inside the range.
By their numbers in this assay, from the lowest: compounds 1, 2, 4 and 3 (each within the scatter of the next, the first and the last beyond it).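

In this assay, among these compounds, the group on this oxygen on a saturated carbon, which no earlier step had touched, goes from benzyl to butylcarbamoyl with a number 6 percentage points higher from compound 2 to compound 4 (within the scatter). The change removes the six-membered aromatic ring and brings in a hydrogen-bond donor and a double bond, yet the number does not move beyond the scatter at the one concentration tested. No measurement shown here explains this outcome.

Going by these compounds, it remains open whether a longer chain on the carbamoyl nitrogen, or an amine or a carboxylic acid in place of butylcarbamoyl, would move the number beyond the scatter. On these data alone, it is also open whether butylcarbamoyl would give a similar result when combined with the phenethyl-bearing amine of compound 3.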